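The compounds below may be only part of what the source reports. "The series", "measured", "known", "first", "only" and "open" are said of these compounds alone.

Compound 1 `COc1cc(N2C(N)=C(C#N)C(c3ccc(OC)c4ccccc34)C3=C2CC(C)(C)CC3=O)cc(OC)c1OC` gives 10% in a functional assay on Ehrlich cells (Mus musculus) for cytotoxicity, tested at 10 ug/mL; on this read-out lower numbers stand for a weaker effect and higher numbers for a stronger effect at the one concentration tested. Among the three measured compounds it stands second highest. Compound 2 `COc1cc(N2C(N)=C(C#N)C(c3ccc(C)cc3)C3=C2CC(C)(C)CC3=O)cc(OC)c1OC` gives 30% in this assay, and the corresponding step is a number 20 percentage points higher from compound 1 to compound 2 (beyond the scatter). Compound 3 `COc1cc(N2C(N)=C(C#N)C(c3c(OC)ccc4ccccc34)C3=C2CC(C)(C)CC3=O)cc(OC)c1OC` gives 0% in this assay; here the step is a number 10 percentage points lower from compound 1 to compound 3 (within the scatter), and a further measured step is a number 30 percentage points lower from compound 2 to compound 3 (beyond the scatter).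

Compound 4 `COc1cc(N2C(N)=C(C#N)C(c3ccc(Cl)cc3Cl)C3=C2CC(C)(C)CC3=O)cc(OC)c1OC` has not yet been measured. Its difference from compound 1 is 2,4-dichlorophenyl in place of 4-methoxynaphthalen-1-yl on a saturated ring carbon. The step from compound 1 to compound 2 bears most directly on this change, since there too a group with two six-membered aromatic rings of carbon only left and a group with one six-membered aromatic ring of carbon only entered, giving a number 20 percentage points higher from compound 1 to compound 2 (beyond the scatter). The step to compound 3, where two rings remained, stayed within the scatter. A modest rise in this assay is therefore expected for compound 4. The estimate for compound 4 is 25%, with a range from 5% to 45%. This estimate corresponds to an expected step of a number 15 percentage points higher from compound 1 to compound 4 (beyond the scatter).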

Compound 4, a percentage reported as activity, at one concentration (the size of the read-out at that concentration, not a potency): 20%
Compound 4: the middle estimate sits 5 percentage points above what was measured; measured number inside the range.
By their numbers in this assay, from the lowest: compounds 3, 1, 4 and 2 (each within the scatter of the next, the first and the last beyond it).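

Exchanging the 4-methoxynaphthalen-1-yl group for 2,4-dichlorophenyl gives a number 10 percentage points higher from compound 1 to compound 4 (within the scatter), and exchanging the 4-methylphenyl group for it gives a number 10 percentage points lower from compound 2 to compound 4 (within the scatter), so in this assay this chlorine-bearing ring cannot be separated from either group. Going by these compounds alone, only the step from 2-methoxynaphthalen-1-yl, a number 20 percentage points higher from compound 3 to compound 4 (beyond the scatter), clears the scatter, so a second single-ring group now stands apart from that naphthalene, while the 4-methoxynaphthalen-1-yl group of compound 1 stands apart from neither single-ring group's neighbour in compound 4. No evidence at hand accounts for these differences.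

Still open, on these data alone, is whether anything at this saturated ring carbon reads clearly above compound 2 at 30%, for instance a pyridin-3-yl ring, a cyclohexyl ring or a carboxylic acid on the phenyl ring. A single chlorine on the phenyl ring, set against the two of compound 4, would also show whether either chlorine matters.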